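The source may hold more compounds than are shown below. What is called first, only, known or untested is meant among the compounds shown, and "the series" means these compounds.

Among the compounds with values here, compound 2 `CC(C(=O)NCc1ccc(C(F)(F)F)cc1-c1ccc(C(C)(C)C)cc1)c1ccc(NS(C)(=O)=O)c(F)c1` gives 1.1 nM in an assay on CHO cells for antagonist activity at transient receptor potential cation channel subfamily V member 1 (Homo sapiens), read by FLIPR (a higher number here means a weaker inhibitor, a lower number a stronger inhibitor), the lowest of the two numbers so far; the nearest is compound 1 `CC(C(=O)NCc1ccc(C(F)(F)F)cc1N1CCC(C)(C)CC1)c1ccc(NS(C)(=O)=O)c(F)c1`, which in this assay gives 1.3 nM, and the step of a 1.2-fold lower number from compound 1 to compound 2 (0.07 log units; within the scatter) stays within the scatter, so the two are not separated. Compound 3 `CC(C(=O)NCc1ccc(C(F)(F)F)cc1-c1cccc(Cl)c1)c1ccc(NS(C)(=O)=O)c(F)c1` is the next member, obtained by the change (3-chlorophenyl in place of 4-(tert-butyl)phenyl on an aromatic carbon), in words 3-chlorophenyl in place of 4-(tert-butyl)phenyl on an aromatic carbon. Within the data shown here, the single measured step, a 1.2-fold lower number from compound 1 to compound 2 (0.07 log units; within the scatter), exchanges groups at the same aromatic carbon but does not touch a chlorophenyl ring, so no step bears directly on the new change; it shows only that the site tolerated one substantial exchange without a shift beyond the scatter. The expected step in this assay is therefore a 2.3-fold higher number from compound 2 to compound 3 (0.36 log units; beyond the scatter), leaning toward a slightly higher number but possibly within the scatter. For compound 3 the estimated value in this assay is 2.5 nM, with a range of 0.8 nM to 8 nM.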

Compound 3, inhibition constant: 1 nM
Compound 3: middle estimate off by 2.5-fold (0.40 log units), on the high side, and the stated range covers the measured number.
By their numbers in this assay, from the lowest: compounds 3, 2 and 1 (each within the scatter of the next).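

In this assay the exchange of 4-(tert-butyl)phenyl for 3-chlorophenyl gives a 1.1-fold lower number from compound 2 to compound 3 (0.04 log units; within the scatter) and the exchange of 4,4-dimethylpiperidin-1-yl for 3-chlorophenyl gives a 1.3-fold lower number from compound 1 to compound 3 (0.11 log units; within the scatter) so neither step separates the compounds. At this aromatic carbon, ortho to a large group and meta to a trifluoromethyl group, the substituent can therefore go from 10 heavy atoms to 7, with chlorine entering and the ring substituent moving from the 4-position to the 3-position, and all three compounds remain within the scatter of one another. No measurement available here accounts for this flat result.

The compounds shown do not reveal what at this carbon would move the number beyond the scatter. A carboxylic acid or an aminomethyl group on the phenyl ring, or a 4-chlorophenyl group, remains an open case.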